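Fluoro to trifluoromethyl: what compound 4 may show

The source may hold more compounds than are shown below. What is called first, only, known or untested is meant among the compounds shown, and "the series" means these compounds.

In a functional assay on V79 cells (Cricetulus griseus) for cytotoxicity, read by colony formation (a higher number here means a weaker inhibitor, a lower number a stronger inhibitor), compound 3 `CC1CN(c2c(F)cc3c(=O)c(C(=O)O)cn(C4CC4)c3c2F)CC(C)N1` gives 150 ug/mL. That value lies within the usual scatter of compound 1 `CNCC1(C)CCN(c2c(F)cc3c(=O)c(C(=O)O)cn(C4CC4)c3c2C(F)(F)F)C1` at 230 ug/mL, so these two cannot be told apart. Compound 2 `O=C(O)c1cn(C2CC2)c2c(C(F)(F)F)c(N3CCNCC3)c(F)cc2c1=O`, at 1650 ug/mL, lies beyond the scatter from both.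

Compound 4 `CC1CN(c2c(F)cc3c(=O)c(C(=O)O)cn(C4CC4)c3c2C(F)(F)F)CC(C)N1` keeps the 3,5-dimethylpiperazin-1-yl group of compound 3 and differs in one place: trifluoromethyl in place of fluoro on an aromatic carbon.

For the measured compounds named here, no measured step covers this change directly. The only one available is a 7.2-fold higher number from compound 1 to compound 2 (0.86 log units; beyond the scatter), a modest step that swaps the piperazin-1-yl group in while trifluoromethyl stays. It shows that compounds carrying trifluoromethyl can differ widely, but it says nothing about replacing fluoro. The only hint is indirect: the two trifluoromethyl compounds, compound 1 at 230 ug/mL and compound 2 at 1650 ug/mL, span a range that starts within the scatter of compound 3 and extends only upward.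

A modest move toward a higher number is therefore expected, though a change within the scatter remains possible. The estimated step is a 2.3-fold higher number from compound 3 to compound 4 (0.37 log units; beyond the scatter). For compound 4 the estimated value is 350 ug/mL, with an expected range from 110 ug/mL to 1200 ug/mL.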

Compound 4, half-maximal inhibitory concentration: > 500 ug/mL
Compound 4 ended at the assay's limit; the forecaster's own chance of this, stated with the estimate: 5%; at least 1.4-fold (0.15 log units) between middle value and limit.
By their numbers in this assay, from the lowest: compounds 3 and 1 (each within the scatter of the next); then compound 2.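

In this assay compound 4 stands at a limit of the assay, so its reading is not a number: the limit of > 500 ug/mL in this assay, at which 1 of the 4 values shown sits.

Even so, with the 3,5-dimethylpiperazin-1-yl group held fixed, trifluoromethyl in place of fluoro gives an at least 3.3-fold higher number from compound 3 to compound 4 (0.52 log units; beyond the scatter), the first direct reading of this change, and it shows that the change at this position moves the number upward, toward a weaker inhibitor. With trifluoromethyl kept, 3,5-dimethylpiperazin-1-yl in place of 3-methyl-3-((methylamino)methyl)pyrrolidin-1-yl gives an at least 2.1-fold higher number from compound 1 to compound 4 (0.33 log units; beyond the scatter), so the group on the neighbouring ortho carbon also shifts the number, while the step between compound 2 and compound 4 cannot be read.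

Going by these compounds, the true size of the trifluoromethyl effect stays open, since the limit gives only a lower bound on the step and a single pair of compounds carries this change. Also open, on these data alone, is whether a methyl group or a chlorine atom at this position would move the number in the same direction, and whether the same change would do so with a different group on the ortho carbon.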